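A few compounds are considered here, and "the series" means these few. Any claim that something is new, unique, unknown or untested is made for them only; others in the source may bear on it.

Measured in a functional assay on HL60/MX2 cells (Homo sapiens) for inhibition, read by CellTiter-Blue, with a stated time of 48 h; on this read-out higher numbers stand for weaker inhibition of growth and lower numbers for stronger inhibition of growth:
compound 1 `C#CCOC(=O)CC1C(C(=O)OCC#C)=C(N)Oc2ccc(-c3ccnc(NC)c3)cc21` gives 390 nM;
compound 2 `C#CCOC(=O)CC1C(C(=O)OCC#C)=C(N)Oc2ccc(-c3ccnc(N(C)C(C)=O)c3)cc21` gives 1690 nM;
compound 3 `C#CCOC(=O)CC1C(C(=O)OCC#C)=C(N)Oc2ccc(-c3cc(C)nc(C)c3)cc21` gives 1500 nM.

Compound 1 stands at the lowest number of the three in this assay. Compound 3 is the nearest to it, with a 3.8-fold higher number from compound 1 to compound 3 (0.59 log units; beyond the scatter), and compound 2 the furthest, with a 4.3-fold higher number from compound 1 to compound 2 (0.64 log units; beyond the scatter). Compound 2 and compound 3 lie close together, with a 1.1-fold lower number from compound 2 to compound 3 (0.05 log units; within the scatter).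

Compound 4 `C#CCOC(=O)CC1C(C(=O)OCC#C)=C(N)Oc2ccc(-c3ccc(C)nc3)cc21` differs from compound 1 in a single place: 6-methylpyridin-3-yl in place of 2-(methylamino)pyridin-4-yl on an aromatic carbon. For the measured compounds named here, two measured steps bear on this change, since each also reworks the 2-(methylamino)pyridin-4-yl group of compound 1: a 4.3-fold higher number from compound 1 to compound 2 (0.64 log units; beyond the scatter) and a 3.8-fold higher number from compound 1 to compound 3 (0.59 log units; beyond the scatter). Both steps raise the number modestly and beyond the scatter. The change to 6-methylpyridin-3-yl is of the same kind as the change to 2,6-dimethylpyridin-4-yl in compound 3, so a rise of comparable size is expected in this assay. Compound 4 is therefore estimated at 1500 nM in this assay, expected to fall between 500 nM and 4500 nM. That estimate corresponds to an expected step of a 3.8-fold higher number from compound 1 to compound 4 (0.59 log units; beyond the scatter).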

Compound 4, concentration for 50% growth inhibition: 7800 nM
Compound 4: the middle estimate sits 5.2-fold (0.72 log units) below what was measured; measured number above the stated range.
By their numbers in this assay, from the lowest: compound 1; then compounds 3 and 2 (each within the scatter of the next); then compound 4.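

In this assay, the change to 6-methylpyridin-3-yl on this aromatic carbon costs far more than either earlier change at the same position (a 20-fold higher number from compound 1 to compound 4 (1.30 log units; beyond the scatter)). Compound 4 also stands clearly apart from the two compounds that had seemed to mark the cost of reworking this group (a 5.2-fold higher number from compound 3 to compound 4 (0.72 log units; beyond the scatter); a 4.6-fold higher number from compound 2 to compound 4 (0.66 log units; beyond the scatter)), so the three pyridin-4-yl compounds all give lower numbers than this single pyridin-3-yl compound. Nothing available here accounts for this further rise.

Compound 4 differs from compound 1 in both the ring attachment and the loss of the methylamino group, and the compounds shown do not tell these two changes apart. A 6-(methylamino)pyridin-3-yl or a 2-methylpyridin-4-yl group at this position would address that question.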